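The source may report more compounds than this note shows. Statements on the series, on what has been measured and on what is new or still open speak of the compounds shown alone.

Going by the values given here, of the two compounds measured so far in a functional assay on MCF7 cells (Homo sapiens) for cytotoxicity, read by MTT assay, with stated times of 3 h and 24 h (a lower number here means a stronger inhibitor, a higher number a weaker inhibitor), compound 2 `COc1ccc(C2=[N+]3C(=Nc4c(-c5ccccc5)c5c(n4[B-]3(F)F)-c3ccc(OC)cc3CC5)C(c3ccccc3)=C2I)cc1` has the lower number and is the stronger inhibitor: compound 2 gives 140 nM, while compound 1 `COc1ccc2c(c1)CCc1c(-c3ccccc3)c3n(c1-2)[B-](F)(F)[N+]1=C(c2ccc(C)cc2)C(Br)=C(c2ccccc2)C1=N3` gives 8100 nM, a gap well beyond the usual scatter of repeat measurements. These two compounds differ in more than one place, so their gap cannot be assigned to any single group.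

Compound 3 `COc1ccc2c(c1)CCc1c(-c3ccccc3)c3n(c1-2)[B-](F)(F)[N+]1=C(c2ccc(C)cc2)C(I)=C(c2ccccc2)C1=N3` departs from compound 2 in one place only: methyl in place of methoxy on an aromatic carbon. In words, this is methyl in place of methoxy on an aromatic carbon, para to a large group, so 4-methoxyphenyl becomes 4-methylphenyl. Among the compounds with values here, no measured pair isolates this change, which leaves only indirect evidence. Compound 1 also carries the 4-methylphenyl group, and its 8100 nM suggests that any move will be towards weaker inhibition. A moderate loss is therefore expected, with an estimated 3.2-fold higher number from compound 2 to compound 3 (0.51 log units; beyond the scatter). In this assay the estimate for compound 3 is 450 nM, with an expected range from 120 nM to 2500 nM.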

Compound 3, half-maximal inhibitory concentration: 410 nM
Estimate against measurement, compound 3: 1.1-fold (0.04 log units) above; the range from low to high includes it.
By their numbers in this assay, from the lowest: compound 2; then compound 3; then compound 1.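

In this assay, going by these compounds alone, the change from 4-methoxyphenyl to 4-methylphenyl can now be read on its own for the first time: it gives a 2.9-fold higher number from compound 2 to compound 3 (0.47 log units; beyond the scatter), a modest but real loss, so the methoxy group at this position is worth keeping. Compound 3 also forms a clean pair with compound 1, and iodo in place of bromo on the double-bonded ring carbon gives a 20-fold lower number from compound 1 to compound 3 (1.30 log units; beyond the scatter), a large step that makes the halogen change the bigger of the two single changes seen so far. Nothing available here explains why either change moves the number in this direction.

Each change is seen only once, on one partner compound, so these compounds cannot tell whether either step would keep its size with the other group altered. They also leave open how a hydroxy group or an amine would compare with methoxy at this place on the aromatic ring, and how chloro would compare with bromo and iodo on the double-bonded ring carbon.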